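The compounds below may be only part of what the source reports. "The series", "measured", "known", "first", "only" and "open" are said of these compounds alone.

In a functional assay on the whole organism for inhibition, with Rattus norvegicus as the target, read by paw edema, with stated times of 30 min and 3 h, at a dose of 0.28 mmol/kg by the oral route (a lower number here means less inhibition, a higher number more inhibition at the dose given (going by the name of the read-out)), compound 3 `COc1ccc(-n2nc(C(=O)Nc3ccc(C(=O)O)cc3)nc2-c2cc(OC)c(OC)c(OC)c2)cc1` gives 109%. Compound 1 `CNC(=O)c1nc(-c2cc(OC)c(OC)c(OC)c2)n(-c2ccc(OC)cc2)n1` gives 109% and compound 2 `CCNC(=O)c1nc(-c2cc(OC)c(OC)c(OC)c2)n(-c2ccc(OC)cc2)n1` gives 101%, so compound 3 is level with compound 1 at the digits shown, the two together the highest of the three numbers, and the step of a number 8 percentage points higher from compound 2 to compound 3 (within the scatter) stays within the scatter.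

Compound 4 `COc1ccc(-n2nc(C(=O)Nc3ccc(O)cc3)nc2-c2cc(OC)c(OC)c(OC)c2)cc1` differs from compound 3 by hydroxy in place of carboxy on an aromatic carbon. Going by the values given here, the measured steps of a number 8 percentage points lower from compound 1 to compound 2 (within the scatter) and no change at the digits printed from compound 1 to compound 3 (within the scatter) each exchange the group on the amide-type nitrogen; none exchanges a group on the aromatic ring, so no measured step bears directly on this change. All three measured steps lie within the scatter, and no step beyond the scatter is therefore expected here either. The expected step is a number 9 percentage points lower from compound 3 to compound 4 (within the scatter). Compound 4 is estimated at 100%, with a range from 80% to 115%.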

Compound 4, a percentage reported as inhibition, in the whole organism at one dose (the size of the read-out at that dose, not a potency): 74%
Compound 4: middle estimate off by 26 percentage points, on the high side; measured number below the stated range.
By their numbers in this assay, from the lowest: compound 4; then compounds 2, 1 and 3 (each within the scatter of the next).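

Going by these compounds alone, the aromatic carbon para to a large group is the first place where an exchange goes beyond the scatter in this assay: hydroxy in place of carboxy gives a number 35 percentage points lower from compound 3 to compound 4 (beyond the scatter) and so separates two groups that differ only there. On the amide-type nitrogen, 4-carboxyphenyl stays within the scatter of methyl and ethyl, whereas 4-hydroxyphenyl does not, giving a number 35 percentage points lower from compound 1 to compound 4 (beyond the scatter) against methyl and a number 27 percentage points lower from compound 2 to compound 4 (beyond the scatter) against ethyl. Nothing available here accounts for this drop.

From the compounds shown here alone, whether the drop follows from the loss of carboxy or from the arrival of hydroxy stays open. Unsubstituted phenyl, a methoxy group or an amine at the same place would help separate the two.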